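Diaryl ether thioureas: chloro to trifluoromethoxy on the aryl thiourea

The source may report more compounds than this note shows. Statements on the series, on what has been measured and on what is new or still open speak of the compounds shown alone.

Compound 1 `CC(C)NC(=O)c1cc(Oc2cccc(NC(=S)Nc3ccc(Cl)cc3)c2)ccn1` is the reference point. In a functional assay on PC-3 cells (Homo sapiens) for cytotoxicity, read by MTT assay, with a stated time of 48 h (on this read-out lower numbers stand for stronger inhibition and higher numbers for weaker inhibition), compound 1 gives 21200 nM, the second highest of the three numbers in hand. Compound 2 `O=C(NCc1ccccc1)c1cc(Oc2cccc(NC(=S)Nc3ccc(Cl)cc3)c2)ccn1` gives 15800 nM in this assay, and the step of a 1.3-fold lower number from compound 1 to compound 2 (0.13 log units; within the scatter) stays within the scatter. Compound 3 `O=C(c1cc(Oc2cccc(NC(=S)Nc3ccc(F)c(F)c3)c2)ccn1)N1CCCC1` gives 45600 nM in this assay, which stands a step beyond the scatter higher than compound 1; compound 3 differs from compound 1 in two places, so only its value is noted.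

Compound 4 `CC(C)NC(=O)c1cc(Oc2cccc(NC(=S)Nc3ccc(OC(F)(F)F)cc3)c2)ccn1` differs from compound 1 by trifluoromethoxy in place of chloro on an aromatic carbon. For the measured compounds named here, no measured step touches this part of the structure: the single step in hand, from compound 1 to compound 2, changes the amide nitrogen substituent and not the aryl thiourea. With nothing to argue for movement in either direction, the expectation for compound 4 in this assay is a step of a 1.2-fold lower number from compound 1 to compound 4 (0.07 log units; within the scatter) of no size beyond the scatter. Compound 4 is therefore estimated at 18000 nM, with a range from 6000 nM to 50000 nM.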

Compound 4, half-maximal inhibitory concentration: 11800 nM
Estimate against measurement, compound 4: 1.5-fold (0.18 log units) above, and the stated range covers the measured number.
By their numbers in this assay, from the lowest: compounds 4, 2 and 1 (each within the scatter of the next); then compound 3.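

In this assay, the aryl thiourea now has a measured step of its own, a 1.8-fold lower number from compound 1 to compound 4 (0.25 log units; within the scatter), so the exchange of chloro for trifluoromethoxy on an aromatic carbon, para to a large group, stays within the scatter. For the compounds shown here, this position therefore accepts 5 heavy atoms in place of 1 with no change that can be read, which the earlier compounds could not show: the step to compound 2 concerns the amide nitrogen, and compound 3 differs from compound 1 in two places. The data in hand give no explanation for this result.

On these data alone, whether the same exchange behaves alike on the benzyl amide of compound 2 remains open. So does the effect of an amine or a carboxylic acid at this position on the aryl thiourea.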